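Phenethyl for aryl on the sulfur: an untested swap

A few compounds are considered here, and "the series" means these few. Any claim that something is new, unique, unknown or untested is made for them only; others in the source may bear on it.

Measured so far:
compound 1 `COc1ccc(SCc2ccc(C(=O)Nc3ccccc3N)cc2)cc1` 73.3%
compound 2 `Cc1cc(C)cc(SCc2ccc(C(=O)Nc3ccccc3N)cc2)c1` 3.22%
compound 3 `CCc1ccc(SCc2ccc(C(=O)Nc3ccccc3N)cc2)cc1` 40.7%

In a functional assay on HCT-116 cells (Homo sapiens) for inhibition, read by CCK-8 assay, with a stated time of 72 h, tested at 2 uM (on this read-out lower numbers stand for less inhibition of growth and higher numbers for more inhibition of growth at the one concentration tested), compound 3 stands second highest of the three, with compound 1 higher by a number 32.6 percentage points lower from compound 1 to compound 3 (beyond the scatter) and compound 2 lower by a number 37.5 percentage points higher from compound 2 to compound 3 (beyond the scatter). Compound 4 `Nc1ccccc1NC(=O)c1ccc(CSCCc2ccccc2)cc1` differs by phenethyl in place of 4-ethylphenyl on a sulfur. Going by the values given here, no measured step swaps an aryl for a chain on that sulfur, so none bears on it directly; the steps of a number 70.1 percentage points lower from compound 1 to compound 2 (beyond the scatter) and a number 37.5 percentage points higher from compound 2 to compound 3 (beyond the scatter) only show that the group on the sulfur moves this read-out widely. Compound 4 is therefore expected near compound 3, with a wide range, the expected step being a number 5.7 percentage points lower from compound 3 to compound 4 (within the scatter). Compound 4 is estimated at 35%, between 5% and 70%.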

Compound 4, percent growth inhibition at one concentration: 30.5%
Estimate against measurement, compound 4: 4.5 percentage points above, and the stated range covers the measured number.
By their numbers in this assay, from the lowest: compound 2; then compound 4; then compound 3; then compound 1.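

In this assay, phenethyl on the sulfur keeps growth inhibition with the same atoms as 4-ethylphenyl joined differently, although the swap gives a number 10.2 percentage points lower from compound 3 to compound 4 (beyond the scatter) as its cost. Set against the other two aryl groups, phenethyl gives a number 27.3 percentage points higher from compound 2 to compound 4 (beyond the scatter) and a number 42.8 percentage points lower from compound 1 to compound 4 (beyond the scatter) and so falls inside their range, which shows that an aryl group directly on the sulfur is not required for this level of inhibition. No measurement here explains these steps.

On these data alone, whether a longer chain or benzyl on the sulfur would hold this inhibition remains open. So does whether a methoxy group or an amine on the phenethyl ring would raise it toward compound 1.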